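This account rests on a few compounds, and the source may have more. Where it says the series, first, only, none or still open, it means among the compounds named here.

In an ADME assay on the whole organism (Rattus norvegicus, strain Sprague-Dawley), read by LC-MS, with a stated time of 30 min, at a dose of 1 mg/kg by the intravenous route (a higher number here means that the compound lasts longer, a lower number that the compound disappears faster), two compounds with a shared core have been measured so far. Compound 1 (`N#Cc1ccc(O[C@H]2CN(S(=O)(=O)c3ccccc3C#N)C[C@@]2(O)CO)cc1F`) gives 0.4 h while compound 2 (`N#Cc1ccc(O[C@H]2CN(S(=O)(=O)c3ccc(Cl)cc3)C[C@@]2(O)CO)cc1F`) gives 1.9 h and so holds the higher of the two numbers. Between them lies a 4.8-fold higher number from compound 1 to compound 2 (0.68 log units; beyond the scatter) and this is the only measured step that bears on what follows, as it too concerns the group on the sulfonyl sulfur. The next compound, compound 3 (`N#Cc1ccc(O[C@H]2CN(S(=O)(=O)c3ccc(C(F)(F)F)nc3)C[C@@]2(O)CO)cc1F`), keeps the shared core and differs from compound 2 by 6-(trifluoromethyl)pyridin-3-yl in place of 4-chlorophenyl on a sulfonyl sulfur in that same place. The earlier step, a 4.8-fold higher number from compound 1 to compound 2 (0.68 log units; beyond the scatter) in size, shows that a swap here can carry the number beyond the scatter. It says nothing about direction for this swap, however, since 6-(trifluoromethyl)pyridin-3-yl has not been measured in this series. Only a small drift away from the higher number of compound 2 is therefore expected, with no change beyond the scatter. The estimated size is a 1.4-fold lower number from compound 2 to compound 3 (0.13 log units; within the scatter) in this assay for now. For compound 3 the expected mean residence time is 1.4 h (estimated range 0.6 h to 3 h).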

Compound 3, mean residence time in the Rattus norvegicus assay: 2.3 h
The estimate for compound 3 lay 1.6-fold (0.22 log units) below the measured number; measured number inside the range.
By their numbers in the Rattus norvegicus assay, from the lowest: compound 1; then compounds 2 and 3 (each within the scatter of the next).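

In the Rattus norvegicus assay, setting 6-(trifluoromethyl)pyridin-3-yl in place of 4-chlorophenyl on the sulfonyl sulfur gives a 1.2-fold higher number from compound 2 to compound 3 (0.08 log units; within the scatter), so this position now holds two different groups that this assay cannot tell apart (compound 2 gives 1.9 h, compound 3 gives 2.3 h), even though the incoming group brings a hetero atom into the aromatic ring and has more heavy atoms. In the Rattus norvegicus assay, the other new step gives a 5.8-fold higher number from compound 1 to compound 3 (0.76 log units; beyond the scatter), so a second group now stands clearly apart from 2-cyanophenyl, and compound 1 is the low member of the set, set off from both compound 2 and compound 3. In a physicochemical assay for lipophilicity, at pH 7.4 (a higher number here means a more lipophilic compound, a lower number a more polar compound), compound 2 gives 4.1 and compound 3 gives 4.2. In the physicochemical assay, the change that links the two higher compounds gives a number 0.10 log units higher from compound 2 to compound 3 (within the scatter), so this pair cannot be told apart in that assay either.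

As far as these compounds go, it remains open whether a group of another kind on the sulfonyl sulfur, such as an amine, a carboxylic acid or a longer alkyl chain, would keep the number at the level of compound 2 and compound 3 or move it away. The material at hand offers no measured explanation for any of these results.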